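The source may report more compounds than this note shows. Statements on the series, on what has been measured and on what is new or still open speak of the compounds shown alone.

Compound 1 `O=C1C=CC2(C=C1)OCC(=O)N2c1nc(-c2ccc3ccccc3c2Br)nn1-c1ccccc1`, compound 2 `CC1OC2(C=CC(=O)C=C2)N(c2nc(-c3cccc4ccccc34)nn2-c2ccccc2)C1=O` and compound 3 `Cc1ccc(-n2nc(-c3ccc4ccccc4c3)nc2N2C(=O)C(C)OC23C=CC(=O)C=C3)cc1` share one core. In a functional assay on A549 cells (Homo sapiens) for antiproliferative activity, with a stated time of 5 days (on this read-out higher numbers stand for weaker inhibition and lower numbers for stronger inhibition), compound 1 gives 100 nM, compound 2 gives 180 nM and compound 3 gives 1210 nM, the highest of the three numbers; compound 2 lies nearer to it and compound 1 further from it, both beyond the scatter. Compound 4 `CC1OC2(C=CC(=O)C=C2)N(c2nc(-c3ccc4ccccc4c3)nn2-c2ccc3ccccc3c2)C1=O` differs from compound 3 in one place: naphthalen-2-yl in place of 4-methylphenyl on an aromatic nitrogen. Within the data shown here, compound 2 and compound 3 differ at that same aromatic nitrogen, and compound 3 gives the higher number of the two; no measured step covers the naphthalen-2-yl group itself. For compound 4 a modest rise in this assay is expected, a 1.5-fold higher number from compound 3 to compound 4 (0.17 log units; within the scatter), with wide uncertainty. Compound 4 is estimated at 1800 nM, between 450 nM and 7000 nM.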

Compound 4, half-maximal inhibitory concentration: 300 nM
Compound 4: middle estimate off by 6.0-fold (0.78 log units), on the high side; the measured number lies below the stated range.
By their numbers in this assay, from the lowest: compounds 1, 2 and 4 (each within the scatter of the next, the first and the last beyond it); then compound 3.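

In this assay, naphthalen-2-yl in place of 4-methylphenyl on the aromatic nitrogen gives a 4.0-fold lower number from compound 3 to compound 4 (0.61 log units; beyond the scatter). Among these compounds, this is the first single-place step available, and it shows that this position responds to the group it carries and accepts a second aromatic ring with stronger inhibition. No measurement shown accounts for the change. Open, on these data alone, is whether the trend extends to other groups at this nitrogen, such as a pyridine ring, a benzyl group or a short alkyl chain. Also open, as far as these compounds go, is whether the same change holds with a different group on the rest of the core.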